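This account rests on a few compounds, and the source may have more. Where it says the series, first, only, none or still open, it means among the compounds named here.

In a functional assay on MCF7 cells (Homo sapiens) for inhibition, read by MTT assay, with a stated time of 72 h (on this read-out lower numbers stand for stronger inhibition and higher numbers for weaker inhibition), compound 1 `Cc1cc(Nc2cc(-c3ccccc3)[nH]n2)n2nc(SCc3c(Cl)cccc3Cl)nc2n1` gives 3230 nM. Compound 2 `Cc1cc(Nc2ccn(Cc3csc4ccc(Cl)cc34)n2)n2nc(SCc3ccc(Br)cc3)nc2n1` gives 2570 nM in this assay. Compound 1 has the highest of the two numbers shown, yet its value and that of compound 2 sit within the usual scatter of repeated measurements, so the two cannot be told apart on this evidence. Compound 3 `Cc1cc(Nc2cc(-c3ccccc3)[nH]n2)n2ncnc2n1` has not yet been measured in this assay. It differs from compound 1 in one place: hydrogen in place of (2,6-dichlorobenzyl)sulfanyl on an aromatic carbon. A sizeable group is removed and nothing is put in its stead, and both measured compounds carry a sulfanyl-bearing group of this kind, so there is no measured case to show what its loss does. The expected outcome is a 4.6-fold higher number from compound 1 to compound 3 (0.67 log units; beyond the scatter), a rise well beyond the scatter, meaning weaker inhibition. For compound 3 the estimate is 15000 nM, with a range from 4000 nM to 60000 nM.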

Compound 3, half-maximal inhibitory concentration: > 50000 nM
Compound 3 ended at the assay's limit; the forecaster's own chance of this, stated with the estimate: 25%; at least 3.3-fold (0.52 log units) between middle value and limit.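

Replacing the (2,6-dichlorobenzyl)sulfanyl group with hydrogen gives an at least 15-fold higher number from compound 1 to compound 3 (1.18 log units; beyond the scatter), so in this assay the substituent on this aromatic carbon is not a spare part of compound 1. Compound 3 gives a limit of the assay, not a number: the limit of > 50000 nM in this assay, at which 1 of the 3 values shown sits.

The size of the step therefore has a lower bound but no known upper end, and compound 1 and compound 2, which both carry a sulfanyl-bearing group here, could not show what its loss does. Going by these compounds, it remains open whether the whole group is needed or only part of it, and a methylsulfanyl group or an amine on the same carbon would help separate the sulfur from the benzyl portion. The chlorine atoms also remain unresolved, as compound 1 and compound 2 differ in more than one place.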